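Aryl ether para-substituent swap in the solubility series

The source may report more compounds than this note shows. Statements on the series, on what has been measured and on what is new or still open speak of the compounds shown alone.

Compound 3 `Clc1ccc(Oc2ccc3c(NCCCNCc4ccco4)ccnc3c2)cc1` stands highest of the three measured compounds in a physicochemical assay for solubility, with a stated time of 18 h, at pH 7.4 (on this read-out lower numbers stand for lower solubility and higher numbers for higher solubility), giving 14500 nM. Compound 1 `c1ccc(CCc2ccc3c(NCCCNCc4ccco4)ccnc3c2)cc1` gives 4200 nM and compound 2 `CC(C)CCc1ccc2c(NCCCNCc3ccco3)ccnc2c1` gives 4200 nM. The steps of a 3.5-fold higher number from compound 1 to compound 3 (0.54 log units; beyond the scatter) and a 3.5-fold higher number from compound 2 to compound 3 (0.54 log units; beyond the scatter) lie beyond the scatter, whereas no change at the digits printed from compound 1 to compound 2 (within the scatter) shows no movement. Compound 4 `COc1ccc(Oc2ccc3c(NCCCNCc4ccco4)ccnc3c2)cc1` differs from compound 3 by methoxy in place of chloro on an aromatic carbon. For the measured compounds named here, no measured step touches the 4-chlorophenoxy group itself; the steps seen all exchange the whole substituent on the core, so they do not bear directly on this change. The step of a 1.0-fold higher number from compound 3 to compound 4 (0.01 log units; within the scatter) is therefore expected to be small, within the scatter, with no firm direction. Compound 4 is estimated at 15000 nM, with a range from 6000 nM to 38000 nM.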

Compound 4, solubility: 14500 nM
The estimate for compound 4 lay 1.0-fold (0.01 log units) above the measured number, within the range that was stated.
By their numbers in this assay, from the lowest: compounds 1 and 2 (each within the scatter of the next); then compounds 3 and 4 (each within the scatter of the next).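

Methoxy in place of chloro, the first change within the outer aromatic group itself, shows no change at the digits printed from compound 3 to compound 4 (within the scatter) in this assay. Compound 4 keeps the standing of compound 3 over the isopentyl and phenethyl compounds, with a 3.5-fold higher number from compound 2 to compound 4 (0.54 log units; beyond the scatter) and a 3.5-fold higher number from compound 1 to compound 4 (0.54 log units; beyond the scatter). Nothing at hand offers a cause for these readings.

On these data alone, whether an amine or a carboxylic acid at this place would also leave the number unmoved stays open. Also open, as far as these compounds go, is whether the higher numbers follow the ether oxygen or the aromatic ring it carries.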